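This account rests on a few compounds, and the source may have more. Where it says the series, first, only, none or still open, it means among the compounds named here.

Measured in a functional assay on K562 cells (Homo sapiens) for cytotoxicity, read by trypan blue exclusion, with a stated time of 96 h; on this read-out higher numbers stand for weaker inhibition and lower numbers for stronger inhibition
- compound 1 `COc1cc(OC)c(/C=C/S(=O)(=O)Cc2ccc(OC)c(N)c2)c(OC)c1` gives 2.5 nM
- compound 2 `COC(=O)CNc1cc(CS(=O)(=O)/C=C/c2c(OC)cc(OC)cc2OC)ccc1OC` gives 100 nM
- compound 3 `COC(=O)C(F)(F)Nc1cc(CS(=O)(=O)/C=C/c2c(OC)cc(OC)cc2OC)ccc1OC` gives 250 nM

Compound 2 holds the second highest of the three numbers. Two large steps lead away from compound 1 (a 40-fold higher number from compound 1 to compound 2 (1.60 log units; beyond the scatter) and a 100-fold higher number from compound 1 to compound 3 (2.00 log units; beyond the scatter)), but both change the nitrogen substituent.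

Compound 4 `COC(=O)C(Nc1cc(CS(=O)(=O)/C=C/c2c(OC)cc(OC)cc2OC)ccc1OC)c1ccc(OC)cc1` has 4-methoxyphenyl in place of hydrogen on a saturated chain carbon bound to a carbonyl carbon and a nitrogen on an aromatic ring. Among the measured compounds shown here, the nearest precedent is the modest change at that carbon (a 2.5-fold higher number from compound 2 to compound 3 (0.40 log units; beyond the scatter)), though no aromatic group has been tested there. A similarly modest rise is therefore expected (a 2.5-fold higher number from compound 2 to compound 4 (0.40 log units; beyond the scatter)). For compound 4 the estimate is 250 nM (expected range 60 nM to 1000 nM).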

Compound 4, half-maximal inhibitory concentration: 150 nM
For compound 4 the middle estimate is 1.7-fold (0.22 log units) above the measured one, within the range that was stated.
By their numbers in this assay, from the lowest: compound 1; then compounds 2, 4 and 3 (each within the scatter of the next, the first and the last beyond it).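

In this assay, 4-methoxyphenyl in place of hydrogen on a saturated chain carbon bound to a carbonyl carbon and a nitrogen on an aromatic ring gives a 1.5-fold higher number from compound 2 to compound 4 (0.18 log units; within the scatter) and so does not separate the two compounds. This carbon therefore carries an aromatic group without a step beyond the scatter, which the difluoro compound could not show. No evidence here explains this result.

Still open, on these data alone, is whether an unsubstituted phenyl at this carbon behaves like 4-methoxyphenyl. Also open, as far as these compounds go, is what a carboxylic acid in place of the methyl ester would do.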